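A methyl on compound 3: the expected solubility step

The source may hold more compounds than are shown below. What is called first, only, known or untested is meant among the compounds shown, and "the series" means these compounds.

Compound 1 `Cc1ccoc1C(=O)Nc1ccc(F)c(-c2nc3ncccc3o2)c1` gives 1.6 ug/mL
Compound 2 `Cc1ccc(NC(=O)c2ccoc2)cc1-c1nc2ncccc2o1` gives 12.5 ug/mL
Compound 3 `Cc1ccoc1C(=O)Nc1cccc(-c2nc3ncccc3o2)c1` gives 6.3 ug/mL

In a physicochemical assay for solubility, read by nephelometry, in phosphate buffer, measured as kinetic solubility, at pH 2 (on this read-out lower numbers stand for lower solubility and higher numbers for higher solubility), compound 3, at 6.3 ug/mL, cannot be told apart from compound 2, at 12.5 ug/mL, and it stands above compound 1, at 1.6 ug/mL. Compound 4 `Cc1ccc(NC(=O)c2occc2C)cc1-c1nc2ncccc2o1` is compound 3 with methyl in place of hydrogen on an aromatic carbon. One measured step involves a change on an aromatic carbon of this kind: a 3.9-fold higher number from compound 1 to compound 3 (0.60 log units; beyond the scatter), a modest step with hydrogen in place of fluoro. There, the compound with hydrogen gave the higher number. Compound 2 also carries a methyl, yet its amide part differs from that of compound 4, so it offers no clean comparison and its value gives no sign of a fall. A small downward step is therefore expected, smaller than the one seen with fluoro. The estimated change is a 1.8-fold lower number from compound 3 to compound 4 (0.26 log units; within the scatter). For compound 4 the expected value is 3.5 ug/mL, within an estimated range of 1.5 ug/mL to 9 ug/mL.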

Compound 4, solubility: 1.6 ug/mL
Compound 4: the middle estimate sits 2.2-fold (0.34 log units) above what was measured; low and high end bracket the measured number.
By their numbers in this assay, from the lowest: compounds 1 and 4 (each within the scatter of the next); then compounds 3 and 2 (each within the scatter of the next).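

In this assay the methyl on this aromatic carbon of a six-membered aromatic ring of carbon only gives a 3.9-fold lower number from compound 3 to compound 4 (0.60 log units; beyond the scatter) and so takes the number beyond the scatter, while methyl in place of fluoro at this place gives no change at the digits printed from compound 1 to compound 4 (within the scatter) and leaves the two groups unseparated on this read-out. With the methyl already in this place, the other part of the molecule also counts: 3-methylfuran-2-yl in place of furan-3-yl on a carbonyl carbon gives a 7.8-fold lower number from compound 2 to compound 4 (0.89 log units; beyond the scatter) and this step is also beyond the scatter. Nothing given here accounts for either step.

Only hydrogen, fluoro and methyl are compared on this aromatic carbon. On these data alone, whether an amine, a carboxylic acid or a longer chain there would read differently stays open, as does whether furan-3-yl would keep its number with fluoro in this place.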